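Swapping a Sulfamoyl for Fluoro on a Shared Core

The source may hold more compounds than are shown below. What is called first, only, known or untested is meant among the compounds shown, and "the series" means these compounds.

Compound 1 `O=C(O)c1cnc2cc(S(=O)(=O)O)ccc2c1O` gives 3090000 nM in an assay on isolated protein with malate dehydrogenase, cytoplasmic (Sus scrofa) as the target; on this read-out lower numbers stand for stronger inhibition and higher numbers for weaker inhibition.
Compound 2 `CC(=O)c1ccc2c(O)c(C(=O)O)cnc2c1` gives 912000 nM in this assay.
Compound 3 `NS(=O)(=O)c1ccc2c(O)c(C(=O)O)cnc2c1` gives 692000 nM in this assay.

Compound 3 holds the lowest of the three numbers, but its gap to compound 2 is within the scatter, as a 1.3-fold lower number from compound 2 to compound 3 (0.12 log units; within the scatter) shows; only compound 1 stands clearly apart, with a 4.5-fold lower number from compound 1 to compound 3 (0.65 log units; beyond the scatter). Compound 4 `O=C(O)c1cnc2cc(F)ccc2c1O` differs from compound 3 in one place: fluoro in place of sulfamoyl on an aromatic carbon. Going by the values given here, no measured step exchanges a sulfamoyl for a fluoro. The two steps that touch this same position were within the scatter or modest, so the change is expected to shift this assay little, leaning slightly toward a higher number because compound 3 already sits at 692000 nM. Compound 4 is therefore estimated at 1100000 nM, between 350000 nM and 3500000 nM, an expected step of a 1.6-fold higher number from compound 3 to compound 4 (0.20 log units; within the scatter).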

Compound 4, half-maximal inhibitory concentration: 11000000 nM
Beside the measured number, compound 4's estimate is 10-fold (1.00 log units) below it; measured number above the stated range.
By their numbers in this assay, from the lowest: compounds 3 and 2 (each within the scatter of the next); then compound 1; then compound 4.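

Going by these compounds alone, at this position on the shared core, the choice of group matters more than the earlier compounds showed: in this assay fluoro gives a 16-fold higher number from compound 3 to compound 4 (1.20 log units; beyond the scatter) and a 12-fold higher number from compound 2 to compound 4 (1.08 log units; beyond the scatter), both large, although sulfamoyl and acetyl lie within the scatter of each other. Even sulfo, which held the highest number until now, is not the poorest group here, as fluoro gives a 3.6-fold higher number from compound 1 to compound 4 (0.55 log units; beyond the scatter). Nothing available accounts for this shift. As far as these compounds go, whether an amine, a carboxylic acid or a chloro on this aromatic carbon would fall with compound 3 or with compound 4 remains open.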